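Swapping the Ring Substituent: Expected Maximal Response of Compound 4

The source may hold more compounds than are shown below. What is called first, only, known or untested is meant among the compounds shown, and "the series" means these compounds.

Three compounds share one core and differ only in the group on the amine nitrogen in a ring. Compound 1 `CC1(OC(=O)N2CCC(O[C@H]3CC[C@H](Oc4cnc(S(C)(=O)=O)cn4)CC3)CC2)CC1` gives 118% in a functional assay on isolated protein for agonist activity at Glucose-dependent insulinotropic receptor (Homo sapiens), read by HTRF and cAMP accumulation; a higher number here means a larger maximal response, a lower number a smaller maximal response. Compound 2 `CS(=O)(=O)c1cnc(O[C@H]2CC[C@H](OC3CCN(C(=O)Oc4ccccc4)CC3)CC2)cn1` gives 116%, and compound 3 `CS(=O)(=O)c1cnc(O[C@H]2CC[C@H](OC3CCN(CC4(C(F)(F)F)CC4)CC3)CC2)cn1` gives 116%, level with compound 2 and together the lowest of the three; the gap to the top is a number 2 percentage points lower from compound 1 to compound 3 (within the scatter). Compound 4 `CC(C)c1noc(CN2CCC(O[C@H]3CC[C@H](Oc4cnc(S(C)(=O)=O)cn4)CC3)CC2)n1` carries 3-isopropyl-1,2,4-oxadiazol-5-yl in place of 1-(trifluoromethyl)cyclopropyl on a saturated chain carbon bound to an amine nitrogen in a ring. The measured exchanges on this nitrogen, a number 2 percentage points lower from compound 1 to compound 2 (within the scatter) and no change at the digits printed from compound 2 to compound 3 (within the scatter), stayed within the scatter, so no step beyond the scatter is expected in this assay for compound 4 either. Compound 4 is therefore expected to give 115%, between 100% and 130%, a step of a number 1 percentage points lower from compound 3 to compound 4 (within the scatter) estimated to lie within the scatter.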

Compound 4, largest response reached (Emax), in percent of the reference or control that the assay uses: 102%
Beside the measured number, compound 4's estimate is 13 percentage points above it; the range from low to high includes it.
By their numbers in this assay, from the lowest: compound 4; then compounds 2, 3 and 1 (each within the scatter of the next).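

Unlike the earlier exchanges on this amine nitrogen, this one moves the maximal response in this assay beyond the scatter: a number 14 percentage points lower from compound 3 to compound 4 (beyond the scatter), and likewise a number 14 percentage points lower from compound 2 to compound 4 (beyond the scatter) and a number 16 percentage points lower from compound 1 to compound 4 (beyond the scatter). The position is therefore not indifferent to what it carries, and the (3-isopropyl-1,2,4-oxadiazol-5-yl)methyl group stands apart from the three earlier groups. No measurement at hand accounts for this step.

Going by these compounds, whether the lower response follows the five-membered aromatic ring or the isopropyl on it remains open. A methyl on that ring, or a pyridine in its place, could begin to separate the two.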